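Adding One Methyl to Compound 2

The source may report more compounds than this note shows. Statements on the series, on what has been measured and on what is new or still open speak of the compounds shown alone.

In a physicochemical assay for lipophilicity, using the shake flask method, in phosphate buffer, measured as octanol-water partition, with a stated time of 24 h, at pH 7.4, tested at 100 uM (a lower number here means a more polar compound, a higher number a more lipophilic compound), compound 1 (`Cc1cc(OCC(C)C)cc(C)c1-c1cccc(COc2ccc(S(=O)(=O)CC(=O)O)cc2)c1`) gives 3.94 while compound 2 (`O=C(O)CS(=O)(=O)c1ccc(OCc2cccc(-c3ccccc3Cl)c2)cc1`) gives 2.47 as its reading. Compound 2 thus holds the lower of the two numbers, and its gap to compound 1 lies beyond the scatter of repeated measurements.

Compound 3 (`Cc1ccc(-c2cccc(COc3ccc(S(=O)(=O)CC(=O)O)cc3)c2)c(Cl)c1`) still awaits measurement. It differs from compound 2 in one place (methyl in place of hydrogen on an aromatic carbon): methyl in place of hydrogen on an aromatic carbon, which turns 2-chlorophenyl into 2-chloro-4-methylphenyl. Going by the values given here, no measured pair of compounds shows this change alone, so any forecast here is rough. The change is small, so a modest upward move is expected in this assay and not a climb to the level of compound 1 at 3.94 in this measurement. The expected step is a number 0.43 log units higher from compound 2 to compound 3 (beyond the scatter) and it may only just clear the scatter or even stay within it. Compound 3 is estimated at 2.9 (expected range 2.55 to 3.3).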

Compound 3, distribution coefficient: 3.05
Compound 3: middle estimate off by 0.15 log units, on the low side; the range from low to high includes it.
By their numbers in this assay, from the lowest: compound 2; then compound 3; then compound 1.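

In this assay, replacing one hydrogen with methyl, which turns 2-chlorophenyl into 2-chloro-4-methylphenyl, gives a number 0.58 log units higher from compound 2 to compound 3 (beyond the scatter). Compounds 2 and 3 are the only pair shown that differ in one place, so this step belongs to a single change at a single spot: an aromatic carbon that is meta to the chloro group and para to a large group, and even so small a change carries the reading past the usual scatter at this spot. Nothing measured here explains why the reading moves by this amount.

The compounds shown leave open whether methyl would give a similar step on another carbon of this ring, or on a ring that lacks the chloro group. They also leave open how the reading would respond if this same carbon carried something other than methyl, such as a longer chain like ethyl, a methoxy group or an amine, and so whether the step seen here is typical of this position or particular to methyl.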